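This account rests on a few compounds, and the source may have more. Where it says the series, first, only, none or still open, it means among the compounds named here.

In a functional assay on MCF7 cells (Homo sapiens) for antiproliferative activity, read by CCK-8 assay, with a stated time of 24 h (on this read-out higher numbers stand for weaker inhibition and lower numbers for stronger inhibition), compound 1 `CCN(CC)Cc1ccc2nc(NC(=O)N/N=C/c3ccccn3)sc2c1` gives > 40000 nM, which is a limit of the measurement and not a number. Compound 2 `CC1CCN(Cc2ccc3nc(NC(=O)N/N=C/c4ccccn4)sc3c2)CC1` gives > 40000 nM, again only a limit. Compound 3 `CCN(CC)Cc1ccc(NC(=O)NN=C(c2ccccn2)c2ccccn2)cc1` gives > 40000 nM, also a limit.

The step that the two limits leave unreadable from compound 1 to compound 2 comes from the change (4-methylpiperidin-1-yl in place of diethylamino on a saturated chain carbon bound to an aromatic carbon), and both of its ends sit at the limit of > 40000 nM in this assay, at which 3 of the 3 values shown sit. Compound 3 carries a different core from compound 1; the difference between the two cores is not broken down here. Among the measured compounds shown here, compound 4 `CC1CCN(Cc2ccc(NC(=O)NN=C(c3ccccn3)c3ccccn3)cc2)CC1` has not yet been measured; it differs from compound 3 by 4-methylpiperidin-1-yl in place of diethylamino on a saturated chain carbon bound to an aromatic carbon, the same change as the one between compound 1 and compound 2.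

Because every value shown so far sits at the limit of > 40000 nM in this assay, at which 3 of the 3 values shown sit, compound 4 is expected to stay at that limit as well. The expected step is a step that the limit leaves unreadable from compound 3 to compound 4. For compound 4 the estimate is 60000 nM, expected between 20000 nM and 200000 nM.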

Compound 4, half-maximal inhibitory concentration: > 40000 nM
Compound 4 was reported as a limit; the forecaster's own chance of this, stated with the estimate: 85%; the middle value does not contradict the limit.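

No size can be read for the step from compound 3 to compound 4, as both results are only limits: the limit of > 40000 nM in this assay, at which 4 of the 4 values shown sit.

The compounds shown leave open how strongly any of them acts in this assay and whether 4-methylpiperidin-1-yl in place of diethylamino changes that.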